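Plasma half-life of a salicylate diester with a nitrooxymethyl arm

The compounds below may be only part of what the source reports. "The series", "measured", "known", "first", "only" and "open" are said of these compounds alone.

The shared core of compound 3 `COc1ccc(C(=O)O[C@@H]2CO[C@H]3[C@@H]2OC[C@@H]3OC(=O)c2ccccc2OC(C)=O)cc1` carries two ester arms, and in an ADME assay on a cell-free system (plasma, Homo sapiens) for metabolic stability, with Plasma (Rattus norvegicus) as the target, read by HPLC, at pH 7.4 (on this read-out lower numbers stand for a shorter-lived compound and higher numbers for a longer-lived compound), compound 3 gives 0.0525 h. Its two relatives sit close by: compound 2 `CC(=O)Oc1ccccc1C(=O)O[C@H]1CO[C@H]2[C@@H]1OC[C@H]2OC(=O)c1ccccc1` gives 0.055 h, and compound 1 `CC(=O)Oc1ccccc1C(=O)O[C@H]1CO[C@H]2[C@@H]1OC[C@H]2OC(=O)c1snnc1C` gives 0.0642 h, so the three numbers lie within the scatter of one another; a 1.0-fold lower number from compound 2 to compound 3 (0.02 log units; within the scatter), a 1.2-fold lower number from compound 1 to compound 2 (0.07 log units; within the scatter) and a 1.2-fold lower number from compound 1 to compound 3 (0.09 log units; within the scatter) all confirm this. Compound 4 `CC(=O)Oc1ccccc1C(=O)O[C@H]1CO[C@H]2[C@@H]1OC[C@H]2OC(=O)c1ccc(CO[N+](=O)[O-])cc1` differs from compound 3 in one place: (nitrooxy)methyl in place of methoxy on an aromatic carbon. Among the measured compounds shown here, the only measured step at the same aromatic carbon, methoxy in place of hydrogen on an aromatic carbon, is a 1.0-fold lower number from compound 2 to compound 3 (0.02 log units; within the scatter), and the exchange of the whole arm on the other carbonyl carbon likewise moved nothing beyond the scatter. For the measured compounds named here, no measured step covers a (nitrooxy)methyl group, so the expectation rests on the flatness of the three numbers. Compound 4 is therefore expected to give 0.05 h in this assay, within a range of 0.025 h to 0.1 h, which means an expected step of a 1.1-fold lower number from compound 3 to compound 4 (0.02 log units; within the scatter).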

Compound 4, half-life: 0.1 h
Estimate against measurement, compound 4: 2.0-fold (0.30 log units) below; measured number inside the range.
By their numbers in this assay, from the lowest: compounds 3, 2, 1 and 4 (each within the scatter of the next).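

At this aromatic carbon, para to a large group, the earlier compounds had shown only hydrogen and methoxy; in this assay the (nitrooxy)methyl group extends that series, and the flat picture holds for a group of a quite different kind. Among the compounds shown here, all three steps that reach it stay within the scatter: a 1.9-fold higher number from compound 3 to compound 4 (0.28 log units; within the scatter), a 1.8-fold higher number from compound 2 to compound 4 (0.26 log units; within the scatter) and a 1.6-fold higher number from compound 1 to compound 4 (0.19 log units; within the scatter), so no compound of the four stands apart from the others. Nothing shown here bears on what lies behind these numbers.

As far as these compounds go, whether an amine or a carboxylic acid at this carbon, or a longer chain carrying the nitrooxy group, would move the half-life beyond the scatter remains open. Also open, from the compounds shown here alone, is how the numbers would read with a propionyl group in place of the acetyl group that all four compounds share.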